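The source may hold more compounds than are shown below. What is called first, only, known or untested is meant among the compounds shown, and "the series" means these compounds.

Compound 1 `FC(F)(F)c1c(CN2CCC(c3ccccc3Cl)CC2)ccn2c(CC3CC3)nnc12`: 328%
Compound 2 `Fc1ccc(C2CCN(Cc3ccn4c(CC5CC5)nnc4c3C(F)(F)F)CC2)c(F)c1`: 255%
Compound 3 `Fc1ccc(OC2CCN(Cc3ccn4c(CC5CC5)nnc4c3C(F)(F)F)CC2)c(F)c1`: 272%

All three compounds share one core and differ only in the group carried on a saturated ring carbon. In an assay on CHO cells for positive allosteric modulation of metabotropic glutamate receptor 2 (Homo sapiens), read by scintillation counting, with a stated time of 30 min (on this read-out lower numbers stand for smaller maximal responses and higher numbers for larger maximal responses), compound 3 stands second highest of the three, above compound 2 and below compound 1. The steps show how much that one group matters: a number 73 percentage points lower from compound 1 to compound 2 (beyond the scatter) and a number 56 percentage points lower from compound 1 to compound 3 (beyond the scatter), while a number 17 percentage points higher from compound 2 to compound 3 (beyond the scatter).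

Compound 4 `Fc1ccc(COC2CCN(Cc3ccn4c(CC5CC5)nnc4c3C(F)(F)F)CC2)c(F)c1` is not yet measured. It differs from compound 3 in one place: 2,4-difluorobenzyl in place of 2,4-difluorophenyl on an oxygen on a saturated carbon. Going by the values given here, no measured pair makes exactly this change, so the nearest guide is the modest step seen when an oxygen was inserted between the ring and the aryl group, together with the large swings that followed other changes in this region. In this assay the expected outcome for compound 4 is therefore a step that could lie within the scatter or be a modest decrease, not a large one. The estimate for compound 4 is 250%, with a range from 180% to 320%, which means an expected step of a number 22 percentage points lower from compound 3 to compound 4 (beyond the scatter).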

Compound 4, largest response reached (Emax), in percent of the reference or control that the assay uses in the metabotropic glutamate receptor 2 assay: 332%
Compound 4: middle estimate off by 82 percentage points, on the low side; measured number outside the range, above it.
By their numbers in the metabotropic glutamate receptor 2 assay, from the lowest: compound 2; then compound 3; then compounds 1 and 4 (each within the scatter of the next).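

In the metabotropic glutamate receptor 2 assay, placing 2,4-difluorobenzyl in place of 2,4-difluorophenyl on the oxygen gives a clear gain, with a number 60 percentage points higher from compound 3 to compound 4 (beyond the scatter), and the (2,4-difluorobenzyl)oxy group also improves on the directly attached ring, with a number 77 percentage points higher from compound 2 to compound 4 (beyond the scatter), while a number 4 percentage points higher from compound 1 to compound 4 (within the scatter) shows that it matches the response of the 2-chlorophenyl group. In a physicochemical assay for solubility, read by HPLC, measured as kinetic solubility, at pH 4 (on this read-out lower numbers stand for lower solubility and higher numbers for higher solubility), compound 3 gives > 100000 nM, which is a limit of the assay and not a number. In the physicochemical assay compound 4 gives > 100000 nM, also a limit, so the step from one to the other cannot be read: the limit of > 100000 nM in the physicochemical assay, at which 2 of the 2 values shown sit.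

As far as these compounds go, it stays open whether a longer chain carrying the 2,4-difluorophenyl group would hold this response. From the compounds shown here alone, it is equally open what an amine or a carboxylic acid would do in place of the 2,4-difluorobenzyl group.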